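The compounds below may be only part of what the source reports. "The series", "measured", "known", "first", "only" and "open" are said of these compounds alone.

Compound 1 `CCCNCc1cc(-c2c(C(=O)NCC)noc2-c2cc(C(C)C)c(O)cc2O)on1` is one of three compounds sharing a core in which only the group on one five-membered aromatic ring is varied. In a functional assay on HCT-116 cells (Homo sapiens) for inhibition (a higher number here means a weaker inhibitor, a lower number a stronger inhibitor), compound 1 gives 117 nM, the second highest of the three numbers. Compound 2 `CCNC(=O)c1noc(-c2cc(C(C)C)c(O)cc2O)c1-c1cc(CNC(C)=O)no1` gives 167 nM, and compound 3 `CCNC(=O)c1noc(-c2cc(C(C)C)c(O)cc2O)c1-c1cc(CN2CCCC2)no1` gives 51 nM. The step of a 1.4-fold higher number from compound 1 to compound 2 (0.15 log units; within the scatter) lies within the scatter, while a 2.3-fold lower number from compound 1 to compound 3 (0.36 log units; beyond the scatter) and a 3.3-fold lower number from compound 2 to compound 3 (0.52 log units; beyond the scatter) are modest.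

Compound 4 `CCNC(=O)c1cc(-c2c(C(=O)NCC)noc2-c2cc(C(C)C)c(O)cc2O)on1` has not yet been measured. It differs from compound 1 by ethylcarbamoyl in place of (propylamino)methyl on an aromatic carbon. For the measured compounds named here, the closest comparison among the measured steps is a 1.4-fold higher number from compound 1 to compound 2 (0.15 log units; within the scatter), where exchanging the group on the amine nitrogen left the number within the scatter; the only step that moved the number beyond the scatter, a 2.3-fold lower number from compound 1 to compound 3 (0.36 log units; beyond the scatter), went in a direction that compound 4 does not follow. Compound 4 is therefore expected to sit close to compound 1, with at most a small shift toward a higher number, a step of about a 1.3-fold higher number from compound 1 to compound 4 (0.11 log units; within the scatter). The estimate for compound 4 in this assay is 150 nM, with a range from 60 nM to 400 nM.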

Compound 4, half-maximal inhibitory concentration: 14 nM
Beside the measured number, compound 4's estimate is 11-fold (1.03 log units) above it; the whole stated range lies above it.
By their numbers in this assay, from the lowest: compound 4; then compound 3; then compounds 1 and 2 (each within the scatter of the next).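

The earlier compounds shown here varied only what hangs on a saturated chain carbon at this ring position, and that gave steps no larger than modest. Replacing the whole side group with ethylcarbamoyl, attached directly to the aromatic carbon, gives an 8.4-fold lower number from compound 1 to compound 4 (0.92 log units; beyond the scatter) in this assay, although the counted heavy atoms, donors and acceptors of the two groups match, and it also gives a 3.6-fold lower number from compound 3 to compound 4 (0.56 log units; beyond the scatter). An amide in the side group is not enough on its own, since the acetamidomethyl group of compound 2 sits further from the ring and the change from it gives a 12-fold lower number from compound 2 to compound 4 (1.08 log units; beyond the scatter).

Nothing available explains why the carbamoyl group gives the lowest number here. From the compounds shown here alone, it remains open whether the amide hydrogen is needed, and whether a methyl ester, a carboxylic acid or a longer chain on the amide nitrogen would keep this number.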